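The source may report more compounds than this note shows. Statements on the series, on what has been measured and on what is new or still open speak of the compounds shown alone.

Compounds measured in a functional assay on A549 cells (Homo sapiens) for inhibition, read by MTT assay, with a stated time of 48 h; on this read-out higher numbers stand for weaker inhibition and lower numbers for stronger inhibition:
Compound 1 `CC(C)N1CCn2nc(-c3ccc(Cl)cc3)cc2C1=O` gives 31000 nM.
Compound 2 `CC(C)N1CCn2nc(-c3ccccc3)cc2C1=O` gives a limit of the assay, > 64000 nM.
Compound 3 `COc1ccc(-c2cc3n(n2)CCN(Cc2ccc(Cl)nc2)C3=O)cc1` gives a limit of the assay, > 64000 nM.

Compound 3 is the methoxy member of the series and stands at the limit of this assay, not at a number; the same limit is shared by compound 2, as noted in the limit of > 64000 nM in this assay, at which 2 of the 3 values shown sit. Compound 4 `COc1ccc(-c2cc3n(n2)CCN(C(C)C)C3=O)cc1` has not been measured. Its change from compound 3 is isopropyl in place of (6-chloropyridin-3-yl)methyl on an amide-type nitrogen in a ring, which leaves the methoxy group on the aryl ring in place. For the measured compounds named here, the only measured step, an at least 2.0-fold higher number from compound 1 to compound 2 (0.31 log units; beyond the scatter), concerns the aryl substituent and not the ring nitrogen, so no measured step bears directly on the change from compound 3 to compound 4. Compound 1 shows that an isopropyl on the ring nitrogen can give a number within range of this assay, while compound 3 shows only a limit. Compound 4 is therefore expected to sit near the top of the measurable range, with the step of an at least 1.4-fold lower number from compound 3 to compound 4 (0.15 log units; that floor lies within the scatter) estimated as small. The estimate for compound 4 in this assay is 45000 nM, with a range of 15000 nM to 150000 nM.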

Compound 4, half-maximal inhibitory concentration: > 64000 nM
Compound 4: only a limit was reported; the forecaster's own chance of this, stated with the estimate: 50%; at least 1.4-fold (0.15 log units) between middle value and limit.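

In this assay, isopropyl in place of (6-chloropyridin-3-yl)methyl on the amide-type nitrogen in a ring does not bring the methoxy member to a number: compound 4 gives only a limit of the assay, > 64000 nM. With isopropyl held on that nitrogen, the chloro member alone reads as a number, and methoxy in place of chloro gives an at least 2.0-fold higher number from compound 1 to compound 4 (0.31 log units; beyond the scatter). The steps to compound 4 from compound 2 and from compound 3 cannot be read, so neither the nitrogen change nor methoxy against hydrogen has a size here, and most of the set offers no number to compare: the limit of > 64000 nM in this assay, at which 3 of the 4 values shown sit.

On these data alone, how far compound 2, compound 3 and compound 4 lie past that limit stays open. Also open, as far as these compounds go, is whether bromo in place of chloro on the aryl ring, or an amine on a longer chain at the ring nitrogen, would give a number.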